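Adding a methoxy group to a urea-linked benzyl arm

This account rests on a few compounds, and the source may have more. Where it says the series, first, only, none or still open, it means among the compounds named here.

The series rests on a shared core carrying a phenyl group, two methyl groups on the fused benzene ring and a methyl on the ring nitrogen. Compound 1 `COc1ccccc1CN(C)Cc1c(-c2ccccc2)c2cc(C)c(C)cc2c(=O)n1C` carries an aminomethyl arm bearing a methyl and a 2-methoxybenzyl group; in an assay on IM-9 cells for binding affinity to Substance-P receptor (Homo sapiens) (on this read-out higher numbers stand for weaker inhibition and lower numbers for stronger inhibition), compound 1 gives 800 nM. Compound 2 `Cc1cc2c(-c3ccccc3)c(NC(=O)N(C)Cc3ccccc3)n(C)c(=O)c2cc1C` instead carries a urea whose far nitrogen bears a methyl and a benzyl group, and in this assay compound 2 gives 16 nM, the lower of the two numbers and the stronger of the two measured inhibitions.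

Compound 3 `COc1ccccc1CN(C)C(=O)Nc1c(-c2ccccc2)c2cc(C)c(C)cc2c(=O)n1C` keeps the urea of compound 2 and changes only the benzyl group: methoxy in place of hydrogen on an aromatic carbon. For the measured compounds named here, no measured pair shows this change on its own, so its effect is open. Compound 2 already gives a low number, so compound 3 is expected to stay close to it; the expected step of a 1.1-fold lower number from compound 2 to compound 3 (0.03 log units; within the scatter) is small and within the scatter. Compound 3 is therefore estimated at 15 nM, with a range from 4 nM to 60 nM.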

Compound 3, half-maximal inhibitory concentration: 23 nM
Compound 3: middle estimate off by 1.5-fold (0.19 log units), on the low side; low and high end bracket the measured number.
By their numbers in this assay, from the lowest: compounds 2 and 3 (each within the scatter of the next); then compound 1.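

For the compounds shown here, this is the first pair to isolate methoxy in place of hydrogen on an aromatic carbon, and in this assay it gives the step of a 1.4-fold higher number from compound 2 to compound 3 (0.16 log units; within the scatter). With the urea held constant, the benzyl and 2-methoxybenzyl forms of the arm therefore cannot be told apart on this read-out, and compound 3 joins compound 2 in the low range of numbers, the two lying within the scatter of each other. No available evidence bears on this result or offers an account of it.

As far as these compounds go, what a different group on the same aromatic carbon would do remains open, whether a chlorine atom, a hydroxyl group or a longer ethoxy chain, and so does the reading for methoxy on another carbon of this ring. Also open is whether the 2-methoxybenzyl group makes any difference on the aminomethyl arm of compound 1, since the compounds shown offer no single-change partner for that compound.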